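The compounds below may be only part of what the source reports. "The series", "measured", "known", "first", "only" and "open" are said of these compounds alone.

In an in vitro assay on BTI-TN-5B1-4 cells for inhibition of Amine oxidase [flavin-containing] A (Homo sapiens), read by fluorescence (on this read-out lower numbers stand for stronger inhibition and higher numbers for weaker inhibition), compound 3 `Cc1cccc(Cl)c1NC(=O)c1cc2ccc(OCc3ccc(F)cc3)cc2oc1=O` gives 59600 nM, the second highest of the three numbers recorded so far. Compound 2 `CC(C)NC(=O)c1cc2ccc(OCc3ccccc3)cc2oc1=O` gives 63500 nM in this assay, a number within the usual scatter of that of compound 3. Compound 1 `Cc1cccc(C)c1NC(=O)c1cc2ccccc2oc1=O` gives 9790 nM in this assay, a number clearly lower than that of compound 3. Compound 4 `COc1cc(NC(=O)c2cc3ccc(OCc4ccc(F)cc4)cc3oc2=O)cc(OC)c1` carries 3,5-dimethoxyphenyl in place of 2-chloro-6-methylphenyl on an amide-type nitrogen. Going by the values given here, no measured pair shows this change. Compound 4 is expected to stay close to compound 3, with a step of a 1.2-fold lower number from compound 3 to compound 4 (0.08 log units; within the scatter) in this assay that lies within the scatter. On this basis compound 4 is estimated to give 50000 nM in this assay, with a likely range from 15000 nM to 160000 nM.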

Compound 4, half-maximal inhibitory concentration: 52600 nM
Compound 4: middle estimate off by 1.1-fold (0.02 log units), on the low side; the range from low to high includes it.
By their numbers in this assay, from the lowest: compound 1; then compounds 4, 3 and 2 (each within the scatter of the next).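

In this assay, 3,5-dimethoxyphenyl in place of 2-chloro-6-methylphenyl on the amide-type nitrogen gives a 1.1-fold lower number from compound 3 to compound 4 (0.05 log units; within the scatter), a step within the usual scatter. In this one pair, the read-out therefore does not separate the two substituted phenyl groups, although the entering group carries hydrogen-bond acceptors and the leaving group carries none. No evidence at hand bears on this result. Going by these compounds, what remains open is how a group other than a phenyl ring, such as a carboxylic acid or an aminoethyl chain, would read on this nitrogen.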